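From pyridin-4-yl to chloro on the shared core

The compounds below may be only part of what the source reports. "The series", "measured", "known", "first", "only" and "open" are said of these compounds alone.

Measured in a physicochemical assay for solubility, using the shake flask method, in simulated intestinal fluid, measured as kinetic solubility, with a stated time of 2 h, at 25 degrees C, at pH 6.5 (a higher number here means a more soluble compound, a lower number a less soluble compound), are two compounds:
Compound 1 `COC(=O)c1nc(C)c2c(c1N)C(=O)N(Cc1ccccc1)C2=O` gives 7400 nM
Compound 2 `Cc1noc(-c2nc(C)c3c(c2N)C(=O)N(Cc2ccc(-c4ccncc4)cc2)C3=O)n1` gives < 5000 nM as a limit

Compound 2 has no number of its own, only the limit < 5000 nM in this assay and nothing more exact. Compound 3 `Cc1noc(-c2nc(C)c3c(c2N)C(=O)N(Cc2ccc(Cl)cc2)C3=O)n1` differs from compound 2 in one place: chloro in place of pyridin-4-yl on an aromatic carbon, para to a large group (chloro in place of pyridin-4-yl on an aromatic carbon). Going by the values given here, no measured pair of compounds shows a change in one place, so no step beyond the scatter is expected, in either direction. The expected step is a step that the limit leaves unreadable from compound 2 to compound 3 in this assay. Compound 3 is estimated at 4000 nM with an expected range from 1500 nM to 9000 nM.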

Compound 3, solubility: < 5000 nM
Compound 3 was reported as a limit (the forecaster's own chance of this, stated with the estimate: 65%); the middle value is on the limit's open side.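

In this assay, going by these compounds alone, compound 2 and compound 3 are both reported only as limits, so no step between them can be read. The compounds shown leave open whether chloro in place of pyridin-4-yl changes the solubility at all.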